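The source may hold more compounds than are shown below. What is called first, only, known or untested is meant among the compounds shown, and "the series" means these compounds.

Measured compounds:
- compound 1, `O=[N+]([O-])c1cc(OCc2ccccc2)ccc1CNc1cc(C(F)(F)F)cc2[nH]ncc12`: 97000 nM in an assay for inhibition of Tryptophan 2,3-dioxygenase (Homo sapiens), with stated times of 10 min and 60 min; a lower number here means a stronger inhibitor, a higher number a weaker inhibitor
- compound 2, `N#Cc1cc(NCc2ccccc2[N+](=O)[O-])c2cn[nH]c2c1`: > 100000 nM in this assay
- compound 3, `O=[N+]([O-])c1ccc(Cl)cc1CNc1cc(C(F)(F)F)cc2[nH]ncc12`: 3190 nM in this assay

Three compounds share a core and differ in the group on the six-membered aromatic ring that carries a nitro group. In this assay compound 3 gives 3190 nM, the lowest of the two numbers recorded. The nearest measured neighbour is compound 1, which in this assay gives 97000 nM, a much higher number, well beyond the scatter of the assay. The value for compound 2 is a limit of the assay, not a number: it sits at the limit of > 100000 nM in this assay, at which 1 of the 3 values shown sits.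

Compound 4, `O=[N+]([O-])c1ccccc1CNc1cc(C(F)(F)F)cc2[nH]ncc12`, has not yet been measured in this assay. It differs from compound 3 in one place: hydrogen in place of chloro on an aromatic carbon. In other words, hydrogen in place of chloro on an aromatic carbon, para to a nitro group.

Among the compounds with values here, no measured pair in this set makes exactly this change, so the expected size of the step rests on the change itself rather than on a recorded step. Removing the chloro leaves a smaller ring substituent, and the expectation is a modest loss, a 3.1-fold higher number from compound 3 to compound 4 (0.50 log units; beyond the scatter), beyond the scatter but not large. Compound 4 is therefore estimated at 10000 nM, with a plausible range from 3000 nM to 40000 nM.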

Compound 4, half-maximal inhibitory concentration: 2550 nM
Estimate against measurement, compound 4: 3.9-fold (0.59 log units) above; measured number below the stated range.
By their numbers in this assay, from the lowest: compounds 4 and 3 (each within the scatter of the next); then compound 1. At a limit, above all of these: compound 2.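

In this assay, the chloro para to a nitro group makes no readable difference: the step is a 1.3-fold lower number from compound 3 to compound 4 (0.10 log units; within the scatter), so this change leaves the number effectively unchanged, and compound 3 and compound 4 cannot be told apart. Benzyloxy behaves quite differently: hydrogen in its place on an aromatic carbon gives a 38-fold lower number from compound 1 to compound 4 (1.58 log units; beyond the scatter), which shows that the ring carrying the nitro group does not tolerate every substituent equally, even though compound 1 and compound 3 do not carry their groups on the same carbon. Trifluoromethyl in place of cyano gives an at least 39-fold lower number from compound 2 to compound 4 (1.59 log units; beyond the scatter), a large step whose true size stays unknown, since compound 2 stands at a limit of the assay and not at a number: the limit of > 100000 nM in this assay, at which 1 of the 4 values shown sits.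

The compounds shown leave open how a methoxy group or an amine on the carbon that held the chloro would read, and so whether any group there can lower the number. They also leave open what a carboxylic acid in place of the nitro group would do.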